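The compounds below may be only part of what the source reports. "The series", "measured", "known", "first", "only" and "open" are said of these compounds alone.

Compound 3 `COc1cc(-c2nnc3n2NC(c2ccco2)C(C(=O)c2ccc(Br)cc2)S3)cc(OC)c1OC` is the point of departure. In a functional assay on HepG2 cells (Homo sapiens) for cytotoxicity, read by MTT assay, with a stated time of 48 h (on this read-out higher numbers stand for weaker inhibition and lower numbers for stronger inhibition), compound 3 gives > 100000 nM, which is a limit of the assay and not a number. Its relatives share the same core. Compound 1 `COc1cc(-c2nnc3n2NC(c2ccco2)C(C(=O)c2cccs2)S3)cc(OC)c1OC` gives 64100 nM in this assay. Compound 2 `COc1cc(-c2nnc3n2NC(c2ccco2)C(C(=O)c2ccc(-c4ccccc4)cc2)S3)cc(OC)c1OC` gives > 100000 nM in this assay, again a limit of the assay. The exchange of thiophen-2-yl for 4-bromophenyl on the carbonyl carbon reads an at least 1.5-fold higher number from compound 1 to compound 3 (0.19 log units; that floor lies within the scatter), and that for 4-phenylphenyl reads an at least 1.5-fold higher number from compound 1 to compound 2 (0.19 log units; that floor lies within the scatter); between compound 2 and compound 3 the step is a step that the two limits leave unreadable from compound 2 to compound 3. Compound 4 `COc1cc(-c2nnc3n2NC(c2ccco2)C(C(=O)c2ccc(O)cc2)S3)cc(OC)c1OC` differs from compound 3 at one place: hydroxy in place of bromo on an aromatic carbon. Going by the values given here, no measured step swaps bromo for hydroxy, so the two limits are the only guide. Compound 4 is expected to stay at that level because the limit of > 100000 nM in this assay, at which 2 of the 3 values shown sit, shows where its closest relatives sit, with a number no higher from compound 3 to compound 4 (the limit leaves the size open) amounting to no change beyond the scatter. The estimate for compound 4 in this assay is 100000 nM, within 30000 nM to 300000 nM.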

Compound 4, half-maximal inhibitory concentration: > 100000 nM
Compound 4: a limit, no number; the forecaster's own chance of this, stated with the estimate: 65%; the middle value lies on the limit itself.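

In this assay, going by these compounds alone, the aromatic carbon para to a large group had so far carried only bromo and phenyl, and hydroxy, which brings a hydrogen-bond donor and a hydrogen-bond acceptor that bromo lacks, leaves the series where it stood: the limit of > 100000 nM in this assay, at which 3 of the 4 values shown sit. The steps among compound 2, compound 3 and compound 4 cannot be read, as both ends of each are limits. Within the data shown here, the one readable step, against thiophen-2-yl on the carbonyl carbon, is an at least 1.5-fold higher number from compound 1 to compound 4 (0.19 log units; that floor lies within the scatter), so 4-hydroxyphenyl is not set apart from thiophen-2-yl beyond the scatter.

Going by these compounds, it remains open whether any group at this place on the phenyl ring would bring a number under the limit. An amine or a carboxylic acid there would be the next groups to read against bromo and hydroxy.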